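Removing the indole methyl in a dinitrile antiproliferative series

A few compounds are considered here, and "the series" means these few. Any claim that something is new, unique, unknown or untested is made for them only; others in the source may bear on it.

The study concerns small indole-bearing compounds tested in a functional assay on MT4 cells (Homo sapiens) for antiproliferative activity, read by MTT assay, with a stated time of 96 h; on this read-out higher numbers stand for an effect only at larger amounts of compound and lower numbers for an effect already at smaller amounts. Compound 1, with the structure `CCOC(=O)/C(=C/c1c[nH]c2ccccc12)C(=O)c1ccc([N+](=O)[O-])cc1`, gives a value of 100000 nM in this assay. Compound 2, with the structure `Cc1[nH]c2ccccc2c1C=C(C#N)C#N`, gives 56000 nM in this assay. Among the measured compounds shown here, of the two numbers so far, that of compound 2 is the lower one, but its nearest neighbour is compound 1 and the gap between the two stays within the usual scatter, so the two compounds cannot be told apart on these data.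

The next compound, compound 3, has the structure `N#CC(C#N)=Cc1c[nH]c2ccccc12`. It differs from compound 2 in one place: hydrogen in place of methyl on an aromatic carbon. For the measured compounds named here, whether this change matters has not been tested on any pair of measured compounds in this set, so no measured step exists to lean on. Given how close compound 1 and compound 2 lie, the expectation is that the step of a 1.1-fold higher number from compound 2 to compound 3 (0.03 log units; within the scatter) stays within the scatter, in no particular direction. Compound 3 is therefore estimated at 60000 nM in this assay, within a range from 20000 nM to 150000 nM.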

Compound 3, half-maximal effective concentration: 36000 nM
Beside the measured number, compound 3's estimate is 1.7-fold (0.22 log units) above it; low and high end bracket the measured number.
By their numbers in this assay, from the lowest: compounds 3, 2 and 1 (each within the scatter of the next, the first and the last beyond it).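

Among the compounds shown here, this pair gives the first measured step at this position: in this assay, putting hydrogen in place of methyl on the aromatic carbon next to the ring nitrogen gives a 1.6-fold lower number from compound 2 to compound 3 (0.19 log units; within the scatter). The two compounds therefore cannot be told apart on this read-out, and the methyl, a single carbon, can be exchanged for hydrogen at this place without a change that rises above the scatter. Nothing among the available data bears on the reason for this outcome.

The compounds shown leave open how this place responds to anything other than methyl and hydrogen, such as an ethyl group, a phenyl ring, an amine or a carboxylic acid, since one step within the scatter says nothing about groups of another kind. They also leave open whether the two nitrile groups of the shared core matter for the read-out, for instance whether exchanging one of them for an ethyl ester or a primary amide, with the rest of the structure kept the same, would shift the number beyond the scatter.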